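Removing a Methyl: What Compound 4 Might Show

This account rests on a few compounds, and the source may have more. Where it says the series, first, only, none or still open, it means among the compounds named here.

Compound 1 `N/C(=N\NC(=S)N1CCOCC1)c1ccccn1`: 69.4%
Compound 2 `Cc1ccnc(/C(N)=N/NC(=S)N2CCOCC2)c1`: 62%
Compound 3 `Cc1ccnc(/C(N)=N/NC(=S)N2CCN(c3ccccn3)CC2)c1`: 44%

In a functional assay on A-431 cells (Homo sapiens) for cytotoxicity, read by MTT assay, with a stated time of 72 h, tested at 10 uM (on this read-out lower numbers stand for less inhibition of growth and higher numbers for more inhibition of growth at the one concentration tested), compound 1 gives 69.4%, compound 2 gives 62% and compound 3 gives 44%. Compound 3 stands lowest of the three, and its steps to compound 2 and to compound 1 are beyond the scatter. The change from compound 2 to compound 1 is hydrogen in place of methyl on an aromatic carbon, and it made a step of a number 7.4 percentage points higher from compound 2 to compound 1 (within the scatter). The difference between the core of compound 2 and the core of compound 3 is not broken down here. Compound 4 `N/C(=N\NC(=S)N1CCN(c2ccccn2)CC1)c1ccccn1` has not yet been measured; it differs from compound 3 by hydrogen in place of methyl on an aromatic carbon, the same change seen between compound 2 and compound 1. Because that earlier step was a number 7.4 percentage points higher from compound 2 to compound 1 (within the scatter), the step from compound 3 to compound 4 is expected to be small as well, about a number 6 percentage points higher from compound 3 to compound 4 (within the scatter). Compound 4 is therefore estimated at 50%, with a likely range from 36% to 64%.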

Compound 4, percent growth inhibition at one concentration: 69%
Beside the measured number, compound 4's estimate is 19 percentage points below it; measured number above the stated range.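

In this assay, going from 4-methylpyridin-2-yl to pyridin-2-yl gave a number 25 percentage points higher from compound 3 to compound 4 (beyond the scatter). The same replacement of methyl by hydrogen on an aromatic carbon did not carry over with the same size from one core to the other: the same change on two cores in this assay, a number 7.4 percentage points higher (within the scatter) from compound 2 to compound 1 and a number 25 percentage points higher (beyond the scatter) from compound 3 to compound 4, 17.6 percentage points apart, beyond the scatter of two such steps This shows that, for these two pairs, the size of the step cannot be transferred directly between the cores, but it does not show why the steps differ, and two pairs set no rule for the series.

The compounds shown carry only methyl or hydrogen at this place. On these data alone, how a chlorine atom, a methoxy group or an amine there would behave on either core remains open.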